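The source may hold more compounds than are shown below. What is called first, only, known or untested is meant among the compounds shown, and "the series" means these compounds.

Series notes, an assay on isolated protein for binding affinity to sphingosine 1-phosphate receptor 2 (Homo sapiens), read by surface plasmon resonance; a lower number here means tighter binding, a higher number weaker binding. Three analogues of the shared core have been measured. Compound 1 `Cn1ncc2c(-c3ccccc3)cc(NNC(=O)Nc3cc(Cl)nc(Cl)c3)nc21` gives 1020 nM. Compound 3 `Cn1nc(C(F)(F)F)c2c(-c3ccccc3)cc(NNC(=O)Nc3cc(Cl)nc(Cl)c3)nc21` carries trifluoromethyl in place of hydrogen on an aromatic carbon of the core and gives 940 nM; the step of a 1.1-fold lower number from compound 1 to compound 3 (0.04 log units; within the scatter) lies within the scatter. Compound 2 `Cn1ncc2c(-c3ccc(F)cc3)cc(NNC(=O)Nc3cc(Cl)nc(OCCF)c3)nc21` differs from compound 1 in more than one place; compound 2 gives 2790 nM, a weaker number than that of compound 1, the gap lying beyond the scatter. Compound 1 thus stands second highest of the three numbers, compound 3 closest and compound 2 furthest.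

Compound 4 `COc1ccc(-c2cc(NNC(=O)Nc3cc(Cl)nc(Cl)c3)nc3c2cnn3C)cc1` is not yet measured. It differs from compound 1 by methoxy in place of hydrogen on an aromatic carbon, which read one bond further out is phenyl to 4-methoxyphenyl. For the measured compounds named here, no measured step touches the phenyl ring alone: the step from compound 1 to compound 3 concerns the core and was within the scatter, and compound 2 alters the phenyl ring only together with a second change, so its gap cannot be laid to either one. There is therefore no basis for expecting a shift beyond the scatter in this assay in either direction. Compound 4 is expected to give 1000 nM (range 400 nM to 2500 nM), an expected step of a 1.0-fold lower number from compound 1 to compound 4 (0.01 log units; within the scatter) that should stay within the scatter.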

Compound 4, dissociation constant: 520 nM
The estimate for compound 4 lay 1.9-fold (0.28 log units) above the measured number; low and high end bracket the measured number.
By their numbers in this assay, from the lowest: compounds 4, 3 and 1 (each within the scatter of the next); then compound 2.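

In this assay, for the compounds shown here, phenyl to 4-methoxyphenyl gives a 2.0-fold lower number from compound 1 to compound 4 (0.29 log units; within the scatter) and is the first change read on this ring alone, since the other ring change comes together with a second change. The aromatic carbon para to a large group therefore takes methoxy, with its 2 heavy atoms and 1 hydrogen-bond acceptor, without a shift beyond the scatter, and this holds for this one group at this one place on the core of compound 1. Going by these compounds alone, nothing measured so far explains the number of compound 4, and a single step within the scatter sets no direction for substitution at this carbon.

As far as these compounds go, it remains open whether a longer chain such as ethoxy or butoxy, a hydroxyl, an amine or a carboxylic acid at this same carbon would also stay within the scatter, or would move the number clearly in either direction. Also open, from the compounds shown here alone, is whether methoxy reads the same way on the trifluoromethyl-bearing core of compound 3, or with a group other than chlorine on the second aromatic ring of the urea side.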